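One Methyl Group Added to a Weak Inhibitor

The source may report more compounds than this note shows. Statements on the series, on what has been measured and on what is new or still open speak of the compounds shown alone.

Measured compounds:
Compound 1, `O=C(NC(=S)Nc1cccc(-c2nc3ccccc3[nH]2)c1)c1ccccc1`, gives > 10000 nM.
Compound 2, `CCOc1ccc(C(=O)NC(=S)Nc2cccc(-c3nc4ccccc4[nH]3)c2)cc1OCC`, gives 8000 nM.
Compound 3, `N#Cc1ccc2[nH]c(-c3cccc(NC(=S)NC(=O)c4ccc5c(c4)OCCO5)c3)nc2c1`, gives "not determined" (no result reported).

These three compounds were tested in a functional assay on HUVEC cells (Homo sapiens) for inhibition, read by colorimetric assay and crystal violet staining, with a stated time of 72 h; a lower number here means a stronger inhibitor, a higher number a weaker inhibitor. Among the measured compounds shown here, compound 2 is the only one with a full number, and in this assay compound 2 gives 8000 nM, which is a weak inhibition. For compound 1 the result > 10000 nM is a limit of the assay rather than a number; it is the limit of > 10000 nM in this assay, at which 1 of the 3 values shown sits. Compound 3 has no reported value, so nothing can be said about it beyond its structure.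

The next compound is compound 4, `CCOc1ccc(C(=O)NC(=S)Nc2cc(-c3nc4ccccc4[nH]3)ccc2C)cc1OCC`. It differs from compound 2 in one place: methyl in place of hydrogen on an aromatic carbon. This is a small change, a single carbon added to a ring that already carries the rest of the molecule. For the measured compounds named here, no pair among the measured compounds shows the effect of such a change, so there is no measured step to lean on. Going by the values given here, with only one full number in hand, the expectation is that the step of no change at the digits printed from compound 2 to compound 4 (within the scatter) stays within the usual scatter, in neither direction. On that basis compound 4 is expected to give about 8000 nM in this assay, likely somewhere between 3000 nM and 20000 nM.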

Compound 4, half-maximal inhibitory concentration: 6000 nM
Beside the measured number, compound 4's estimate is 1.3-fold (0.12 log units) above it, within the range that was stated.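

In this assay, among the compounds shown here, placing a methyl on this aromatic carbon, ortho to a large group and para to a 1H-benzimidazol-2-yl group, gives the first measured step between two compounds that differ in one place: a 1.3-fold lower number from compound 2 to compound 4 (0.12 log units; within the scatter). The two numbers cannot be told apart, so this carbon can carry a methyl with no measurable effect on inhibition, and adding this one carbon does not lift the compound out of the weak range. Compound 1 gives no number to compare with this pair, only a limit: the limit of > 10000 nM in this assay, at which 1 of the 4 values shown sits.

As far as these compounds go, a single methyl at a single position is a narrow test, so it remains open whether a longer chain, an amine or a carboxylic acid on the same carbon would produce a step beyond the scatter, in either direction. For the compounds shown here, it is also open whether a methyl here would behave the same way on a stronger inhibitor, since the only pair that can be read lies among weak compounds and says nothing about how the same change acts elsewhere.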